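Varying the Carbonyl Substituent on a Shared Core

The compounds below may be only part of what the source reports. "The series", "measured", "known", "first", "only" and "open" are said of these compounds alone.

The measured compounds:
Compound 1, `COc1ccc2c(c1)OC(c1cc(OC)c(OC)c(OC)c1)C(C(N)=O)=C2`, in a functional assay for inhibition of nuclear factor NF-kappa-B complex (Homo sapiens) (a lower number here means a stronger inhibitor, a higher number a weaker inhibitor), gives > 50000 nM.
Compound 2, `COc1ccc2c(c1)OC(c1cc(OC)c(OC)c(OC)c1)C(C(=O)N(C)C)=C2`, in this assay gives > 50000 nM.
Compound 3, `COC(=O)C1=Cc2ccc(OC)cc2OC1c1cc(OC)c(OC)c(OC)c1`, in this assay gives 13800 nM.

For compound 1 the value is a limit of this assay rather than a number. The same holds for compound 2, so that two of the three values sit at the limit of > 50000 nM in this assay, at which 2 of the 3 values shown sit. Only compound 3 yields a number: the ester shows an at least 3.6-fold lower number from compound 1 to compound 3 (0.55 log units; beyond the scatter) and an at least 3.6-fold lower number from compound 2 to compound 3 (0.55 log units; beyond the scatter), while a step that the two limits leave unreadable from compound 1 to compound 2 stays unreadable between two limits. Compound 4, `COc1ccc2c(c1)OC(c1cc(OC)c(OC)c(OC)c1)C(C(=O)NC(C)(C)C)=C2`, differs from compound 1 by tert-butyl in place of hydrogen on an amide-type nitrogen. Both amides measured so far sit at the limit and only the ester gives a readable number, so compound 4 is expected to remain at best a weak inhibitor, with an at least 1.2-fold lower number from compound 1 to compound 4 (0.09 log units; that floor lies within the scatter) probably unreadable. The estimate for compound 4 is 40000 nM, in the range 12000 nM to 150000 nM.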

Compound 4, half-maximal inhibitory concentration: 28400 nM
Estimate against measurement, compound 4: 1.4-fold (0.15 log units) above; measured number inside the range.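

Compound 4 is the only amide shown that gives a number in this assay, while compound 1 and compound 2 stay at a limit of the assay: the limit of > 50000 nM in this assay, at which 2 of the 4 values shown sit. Tert-butyl on the amide-type nitrogen gives an at least 1.7-fold lower number from compound 1 to compound 4 (0.24 log units; that floor lies within the scatter) and an at least 1.7-fold lower number from compound 2 to compound 4 (0.24 log units; that floor lies within the scatter), so a real gain over either amide is not established. The ester keeps a modest edge, with a 2.1-fold higher number from compound 3 to compound 4 (0.31 log units; beyond the scatter).

From the compounds shown here alone, whether an ethyl or a phenyl group on that nitrogen would also give a readable number stays open. So does how a carboxylic acid in place of the ester would compare.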